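A few compounds are considered here, and "the series" means these few. Any claim that something is new, unique, unknown or untested is made for them only; others in the source may bear on it.

Working notes on the series. Two cores are compared in a functional assay on MCF7 cells (Homo sapiens) for cytotoxicity, read by sulforhodamine B assay, with a stated time of 48 h; a higher number here means a weaker inhibitor of growth, a lower number a stronger inhibitor of growth. Compound 1 `O=C1C(=O)N(CN2CCN(c3ccnc4cc(Cl)ccc34)CC2)c2cccc(Cl)c21` gives 39100 nM; compound 2 `O=C1C(=O)N(CN2CCN(c3ccnc4cc(Cl)ccc34)CC2)c2cccc(Br)c21` gives 15100 nM. The change between them is bromo in place of chloro on an aromatic carbon and the step is a 2.6-fold lower number from compound 1 to compound 2 (0.41 log units; beyond the scatter). Compound 3 `NC(=S)N/N=C1\C(=O)Nc2cc(Cl)ccc21` gives 17200 nM; the difference between the core of compound 3 and the core of compound 1 is not broken down here. Compound 4 `NC(=S)N/N=C1\C(=O)Nc2cc(Br)ccc21` has not yet been measured; it differs from compound 3 by bromo in place of chloro on an aromatic carbon, the same kind of change as in the pair above, though the place differs: there the carbon is ortho to a fused ring and meta to a fused ring, here it is meta to a fused ring and para to a fused ring. For the measured compounds named here, a step of similar size is expected, a 1.9-fold lower number from compound 3 to compound 4 (0.28 log units; within the scatter), resting on the single earlier step of a 2.6-fold lower number from compound 1 to compound 2 (0.41 log units; beyond the scatter). Compound 4 is thus estimated at 9000 nM, likely between 4000 nM and 20000 nM.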

Compound 4, concentration for 50% growth inhibition: 17900 nM
The estimate for compound 4 lay 2.0-fold (0.30 log units) below the measured number; the range from low to high includes it.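

In this assay, bromo in place of chloro on an aromatic carbon gives a 1.0-fold higher number from compound 3 to compound 4 (0.02 log units; within the scatter), so the step seen on the core of compound 1 does not reappear on the core of compound 3: the same change on two cores in this assay, a 2.6-fold lower number (0.41 log units; beyond the scatter) from compound 1 to compound 2 and a 1.0-fold higher number (0.02 log units; within the scatter) from compound 3 to compound 4, 2.7-fold (0.43 log units) apart, beyond the scatter of two such steps Within this series, the change therefore cannot be carried between these two cores as a fixed step. This does not show whether the core or the place of the halogen accounts for the gap, as the two differ together and each core contributes a single pair.

As far as these compounds go, whether the two steps would agree with the halogen at the same place on both cores remains open. Also open, from the compounds shown here alone, is whether fluoro, methyl or an amine at that carbon would give a number apart from those of compound 3 and compound 4.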